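Aromatic nitrogen substituents: from compound 3 to compound 4

The source may report more compounds than this note shows. Statements on the series, on what has been measured and on what is new or still open speak of the compounds shown alone.

In a functional assay on HT-29 cells (Homo sapiens) for inhibition, read by luminescence and CellTiter-Glo, with a stated time of 24 h (a higher number here means that more compound is needed for the effect, a lower number that less compound is needed), compound 1 (`COCCn1nc(C(=O)N[C@H]2COc3ccccc3N(C)C2=S)nc1Cc1ccccc1`), with 2-methoxyethyl on the aromatic nitrogen, gives 566 nM on the half-maximal read-out. Compound 2 (`CN1C(=S)[C@@H](NC(=O)c2nc(Cc3ccccc3)n(CCCC(F)(F)F)n2)COc2ccccc21`), with 4,4,4-trifluorobutyl there, gives 2380 nM by the same measure. Compound 3 (`CN1C(=S)[C@@H](NC(=O)c2nc(Cc3ccccc3)n(C3CCCCCC3)n2)COc2ccccc21`), with cycloheptyl, gives 5530 nM and holds the highest number of the three.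

Compound 4 (`CN1C(=S)[C@@H](NC(=O)c2nc(Cc3ccccc3)n(CC3CCOC3)n2)COc2ccccc21`) carries (oxolan-3-yl)methyl in place of cycloheptyl on the aromatic nitrogen ((oxolan-3-yl)methyl in place of cycloheptyl on an aromatic nitrogen).

All three measured steps concern this same nitrogen. The nearest guide is a 9.8-fold higher number from compound 1 to compound 3 (0.99 log units; beyond the scatter) on going from 2-methoxyethyl to cycloheptyl, since the entering group, like 2-methoxyethyl, holds an oxygen. Smaller is a 2.3-fold higher number from compound 2 to compound 3 (0.37 log units; beyond the scatter) on going from 4,4,4-trifluorobutyl to cycloheptyl, and a 4.2-fold higher number from compound 1 to compound 2 (0.62 log units; beyond the scatter) separates the two open-chain groups. Among the compounds with values here, no measured compound carries the entering ring, so the reverse of the first step is unlikely to be recovered in full. A step to a lower number in this assay, beyond the scatter, is therefore expected. The expected step is a 5.5-fold lower number from compound 3 to compound 4 (0.74 log units; beyond the scatter) on this reading. For compound 4 the estimated value is 1000 nM (expected range 350 nM to 2800 nM).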

Compound 4, half-maximal effective concentration: 4420 nM
Beside the measured number, compound 4's estimate is 4.4-fold (0.65 log units) below it, and the stated range ends below it.
By their numbers in this assay, from the lowest: compound 1; then compounds 2, 4 and 3 (each within the scatter of the next, the first and the last beyond it).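

In this assay, holding an oxygen in the group on the aromatic nitrogen is not enough to give a low number: (oxolan-3-yl)methyl leaves the result far from that of 2-methoxyethyl, with the step to the ring group (a 7.8-fold higher number from compound 1 to compound 4 (0.89 log units; beyond the scatter)) beyond the scatter. Compound 4 cannot be separated from either group without oxygen, as both its steps lie within the scatter (a 1.3-fold lower number from compound 3 to compound 4 (0.10 log units; within the scatter); a 1.9-fold higher number from compound 2 to compound 4 (0.27 log units; within the scatter)), so the oxygen-bearing ring joins cycloheptyl and 4,4,4-trifluorobutyl, and among the four compounds only the 2-methoxyethyl group of compound 1 stands apart. No measurement shown here gives a reason for this difference between the two oxygen-bearing groups.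

From the compounds shown here alone, what remains open is which feature of 2-methoxyethyl goes with the lower number; a 2-hydroxyethyl or 3-methoxypropyl group on the same nitrogen would bear on the role of the open chain and the distance to its oxygen. Whether an amine such as 2-aminoethyl or a chain ending in a carboxylic acid would fall with compound 1 or with the other three is also unsettled.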